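Fluorinated azo analogue and tolerance in bovine kidney cells

This account rests on a few compounds, and the source may have more. Where it says the series, first, only, none or still open, it means among the compounds named here.

Three compounds have been measured in an ADME assay on MDBK cells (Bos taurus) for cytotoxicity, read by MTT assay, with a stated time of 96 h; a higher number here means that more compound is tolerated, a lower number that less compound is tolerated:

Compound 1, `Cc1c(/N=N/c2cccc(C(F)(F)F)c2)ccc(NC[C@@H]2CCCN3CCCC[C@H]23)c1C`: 52000 nM
Compound 2, `c1ccc(/N=N/c2ccc(NC[C@@H]3CCCN4CCCC[C@H]34)c3c2CCCC3)cc1`: > 100000 nM
Compound 3, `CN(C)CCCNc1ccc(/N=N/c2ccccc2)cc1`: 58000 nM

In this assay compound 1 gives 52000 nM and compound 3 gives 58000 nM, two values that lie within the usual scatter of each other. Compound 2 stands apart: its result of > 100000 nM is a limit of the assay and not a number, so only a range is known for it. For the measured compounds named here, it is the one compound of the three whose value sits at the limit of > 100000 nM in this assay, at which 1 of the 3 values shown sits.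

Compound 4, `Fc1ccc(/N=N/c2ccc(NC[C@@H]3CCCN4CCCC[C@H]34)c3c2CCCC3)c(F)c1`, has not been measured. It differs from compound 2 in one place, (2,4-difluorophenyl in place of phenyl on a double-bonded nitrogen). Going by the values given here, no pair of measured compounds differing in a single place is available, so the size of this step cannot be read from the data. The step from compound 2 to compound 4 is expected to be an at least 1.2-fold lower number from compound 2 to compound 4 (0.09 log units; that floor lies within the scatter), a shift not clearly beyond the scatter, leaning if anything toward less compound being tolerated. Compound 4 is therefore estimated at 80000 nM in this assay, with a likely range from 30000 nM to 200000 nM, and a real chance that only a limit is reported again.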

Compound 4, half-maximal cytotoxic concentration: 11000 nM
Beside the measured number, compound 4's estimate is 7.3-fold (0.86 log units) above it; measured number outside the range, below it.
By their numbers in this assay, from the lowest: compound 4; then compounds 1 and 3 (each within the scatter of the next). At a limit, above all of these: compound 2.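

For the compounds shown here, at the place on a double-bonded nitrogen, putting 2,4-difluorophenyl in place of phenyl gives the first step that can be read in this assay: an at least 9.0-fold lower number from compound 2 to compound 4 (0.95 log units; beyond the scatter). Going by these compounds alone, no earlier pair differed in one place, so this is the first sign that the group held here can by itself change how much compound these cells tolerate, with the rest of the structure held constant. Compound 2 gives a limit and not a number, so only the floor of this step is known, and its true size could be larger: the limit of > 100000 nM in this assay, at which 1 of the 4 values shown sits.

As far as these compounds go, it remains open whether a 2-fluorophenyl or a 4-fluorophenyl at this place would lower the number as far, and so whether one fluorine alone or the pair accounts for the step, or whether a 2,4-dichlorophenyl would act in the same way. Also open, from the compounds shown here alone, is whether 2,4-difluorophenyl in place of phenyl would shift the number to a similar extent in compound 3, which carries a dimethylaminopropyl chain on its other nitrogen.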